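Amide aryl swap on the shared core

The source may hold more compounds than are shown below. What is called first, only, known or untested is meant among the compounds shown, and "the series" means these compounds.

Compound 1 `Cc1ccc(O)c(C(O)(C(F)(F)F)C(F)(F)F)c1` and compound 3 `Oc1c(-c2ccccc2)cccc1C(O)(C(F)(F)F)C(F)(F)F` carry the shared core on a single ring. In an assay on isolated protein for inhibition of tyrosine-protein phosphatase non-receptor type 13 (Homo sapiens), read by spectrophotometry (on this read-out higher numbers stand for weaker inhibition and lower numbers for stronger inhibition), compound 1 gives 454000 nM. Compound 3 gives 449000 nM in this assay, and these two values lie within the scatter of each other. Compound 2 `O=C(COc1ccc2cc(C(O)(C(F)(F)F)C(F)(F)F)c(O)cc2c1)Nc1ccccc1` adds an anilino amide arm to the core. For compound 2 the reading in this assay is a limit of the assay, > 20000 nM, not a number, so its standing is known only through (the limit of > 20000 nM in this assay, at which 1 of the 3 values shown sits). Compound 4 `O=C(COc1ccc2cc(C(O)(C(F)(F)F)C(F)(F)F)c(O)cc2c1)Nc1cccc2ccccc12` differs from compound 2 by naphthalen-1-yl in place of phenyl on an amide-type nitrogen. Going by the values given here, no measured pair shows this change, so no step size is known; the step from compound 2 to compound 4 is expected to be a number no higher from compound 2 to compound 4 (the limit leaves the size open). Compound 4 is estimated at 20000 nM, within 5000 nM to 100000 nM, with a limit reading again likely.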

Compound 4, half-maximal inhibitory concentration: > 20000 nM
Compound 4: a limit, no number (the forecaster's own chance of this, stated with the estimate: 60%); the middle value lies on the limit itself.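

No step can be read between compound 2 and compound 4 in this assay, since both readings are limits of the assay: the limit of > 20000 nM in this assay, at which 2 of the 4 values shown sit. Still open, going by these compounds, is whether naphthalen-1-yl in place of phenyl on the amide-type nitrogen changes inhibition at all.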